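Cytotoxicity on Vero cells: a nitro in place of hydrogen

The compounds below may be only part of what the source reports. "The series", "measured", "known", "first", "only" and "open" are said of these compounds alone.

Measured compounds:
compound 1 `N/C(=N/NC(CC(=O)c1ccc(-n2ccnc2)cc1)c1ccc(F)cc1)c1ccccn1`, 78800 nM
compound 2 `N/C(=N/NC(CC(=O)c1ccc(-n2ccnc2)cc1)c1cccc(Br)c1)c1ccccn1`, 51300 nM
compound 3 `N/C(=N/NC(CC(=O)c1ccc(-n2ccnc2)cc1)c1ccccc1)c1ccccn1`, 63500 nM

In an ADME assay on Vero cells (Chlorocebus sabaeus) for cytotoxicity, read by MTT assay, with a stated time of 72 h (a higher number here means that more compound is tolerated, a lower number that less compound is tolerated), compound 3 gives 63500 nM, a number within the scatter of both compound 1 and compound 2; no order among the three can be read from these values.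

Compound 4 `N/C(=N/NC(CC(=O)c1ccc(-n2ccnc2)cc1)c1cccc([N+](=O)[O-])c1)c1ccccn1` differs from compound 3 in one place: nitro in place of hydrogen on an aromatic carbon. Among the measured compounds shown here, the steps that bear on this are the two other changes on the same aromatic ring, a 1.2-fold lower number from compound 1 to compound 3 (0.09 log units; within the scatter) and a 1.2-fold higher number from compound 2 to compound 3 (0.09 log units; within the scatter), both within the scatter. On that basis no step beyond the scatter is expected for compound 4, and the step of a 1.1-fold lower number from compound 3 to compound 4 (0.02 log units; within the scatter) is the estimate. Compound 4 is therefore expected to give about 60000 nM, with a range of 30000 nM to 120000 nM in this assay.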

Compound 4, half-maximal cytotoxic concentration: 28700 nM
Compound 4: the middle estimate sits 2.1-fold (0.32 log units) above what was measured; measured number below the stated range.
By their numbers in this assay, from the lowest: compounds 4, 2, 3 and 1 (each within the scatter of the next, the first and the last beyond it).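

In this assay, among the compounds shown here, this place on the ring proved able to move the number: nitro in place of hydrogen gives the first step on this ring beyond the scatter (a 2.2-fold lower number from compound 3 to compound 4 (0.34 log units; beyond the scatter)), and 3-nitrophenyl in place of 4-fluorophenyl gives a second (a 2.7-fold lower number from compound 1 to compound 4 (0.44 log units; beyond the scatter)). Nitro in place of bromo stays within the scatter (a 1.8-fold lower number from compound 2 to compound 4 (0.25 log units; within the scatter)), so these two groups are not separated here. No measurement at hand accounts for these steps. On these data alone, whether an amine or a carboxylic acid in the same place would give a similar number remains open.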